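This account rests on a few compounds, and the source may have more. Where it says the series, first, only, none or still open, it means among the compounds named here.

Measured so far:
Compound 1 `O=C(CCc1cccc2c1B(O)OC2)Nc1nccs1`: in an ADME assay on WI-38 cells (Homo sapiens) for cytotoxicity, read by MTT assay, with a stated time of 72 h (a lower number here means a stronger inhibitor, a higher number a weaker inhibitor), compound 1 reports only a limit, > 100000 nM.
Compound 2 `O=C(CCc1cccc2c1B(O)OC2)Nc1ccc(F)cc1`: in this assay compound 2 gives 12000 nM.

Going by the values given here, compound 2 holds the only finite number in the set. Among the compounds with values here, the single measured step, an at least 8.3-fold lower number from compound 1 to compound 2 (0.92 log units; beyond the scatter), concerns the group on the amide nitrogen and is known only as a lower bound because compound 1 sits at the limit of > 100000 nM in this assay, at which 1 of the 2 values shown sits. Compound 3 `O=C(CCc1cccc2c1B(O)OC2)Nc1ccc(-c2ccccc2)cc1` differs from compound 2 by phenyl in place of fluoro on an aromatic carbon. Within the data shown here, no measured step touches this position, so a step within the scatter is expected, a 1.5-fold lower number from compound 2 to compound 3 (0.18 log units; within the scatter). Compound 3 is therefore estimated at 8000 nM, with a range of 2500 nM to 30000 nM.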

Compound 3, half-maximal inhibitory concentration: 32000 nM
The estimate for compound 3 lay 4.0-fold (0.60 log units) below the measured number; the whole stated range lies below it.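

In this assay the aromatic carbon para to a large group proves sensitive to substitution, with a 2.7-fold higher number from compound 2 to compound 3 (0.43 log units; beyond the scatter) for phenyl in place of fluoro. Unlike the step on the amide nitrogen, this one rests on two finite numbers, and the added aromatic ring raises the number rather than lowering it. Nothing available gives a cause for this step.

Two substituents at this position define no trend. As far as these compounds go, how an amine or a methoxy group on the same carbon would read remains open.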